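A Trifluoromethyl Step from a Compound at the Limit

This account rests on a few compounds, and the source may have more. Where it says the series, first, only, none or still open, it means among the compounds named here.

Compound 1 `O=C1C=CC2(C=C1)OCC(=O)N2S(=O)(=O)c1ccccc1` was tested in a functional assay on MDA-MB-231 cells (Homo sapiens) for inhibition, read by sulforhodamine B assay, with a stated time of 74 h; a higher number here means a weaker inhibitor, a lower number a stronger inhibitor. There, compound 1 gives > 10000 nM, which is a limit of the assay and not a number. Compound 2 `O=C1C=CC2(C=C1)OCC(=O)N2S(=O)(=O)c1ccccc1OC(F)(F)F`, with trifluoromethoxy in place of hydrogen on an aromatic carbon, gives > 10000 nM, which is also a limit. Together these two results make up (the limit of > 10000 nM in this assay, at which 2 of the 2 values shown sit).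

Compound 3 `O=C1C=CC2(C=C1)OCC(=O)N2S(=O)(=O)c1cccc(C(F)(F)F)c1` changes the core of compound 1 in a related way: trifluoromethyl in place of hydrogen on an aromatic carbon. Here, trifluoromethyl replaces hydrogen on an aromatic carbon, meta to a large group.

Among the measured compounds shown here, the only measured step, a step that the two limits leave unreadable from compound 1 to compound 2, gives no readable size, so no clear gain or loss is expected in this assay. The expected result is a number no higher from compound 1 to compound 3 (the limit leaves the size open), and a further limit is quite likely. For compound 3 the estimated value is 10000 nM, with an expected range from 3000 nM to 30000 nM.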

Compound 3, half-maximal inhibitory concentration: > 10000 nM
Compound 3: no number, only a limit (the forecaster's own chance of this, stated with the estimate: 70%); the middle value lies on the limit itself.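

Among the compounds shown here, compound 3, like compound 1 and compound 2, sits at a limit of the assay and not at a number, so no step between them can be read: the limit of > 10000 nM in this assay, at which 3 of the 3 values shown sit.

The compounds shown leave open how strongly each one inhibits in this assay and whether trifluoromethyl or trifluoromethoxy changes that at all.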